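The source may hold more compounds than are shown below. What is called first, only, known or untested is meant among the compounds shown, and "the series" means these compounds.

Measured in a functional assay on MCF7 cells (Homo sapiens) for inhibition, read by radiometric assay and XTT assay; a higher number here means a weaker inhibitor, a lower number a stronger inhibitor
compound 1 `CCCCCCCC[C@@]1(C)SC(=O)C=C1OC` gives 16.4 ug/mL
compound 2 `C=CCOC1=CC(=O)S[C@]1(C)CCCCCCCC` gives 14.5 ug/mL
compound 3 `C=CCNC(=O)COC1=CC(=O)S[C@]1(C)CCCCCCCC` gives 12.1 ug/mL

Compound 3 stands within the scatter of both other compounds, with a 1.2-fold lower number from compound 2 to compound 3 (0.08 log units; within the scatter) and a 1.4-fold lower number from compound 1 to compound 3 (0.13 log units; within the scatter) as its steps. Compound 4 `CCCCCCCC[C@@]1(C)SC(=O)C=C1OC(=O)CC`, not yet measured, keeps the shared core but carries propanoyl in place of (allylcarbamoyl)methyl on an oxygen on an unsaturated carbon. Among the measured compounds shown here, the steps that bear on this change sit on the same oxygen, a 1.1-fold lower number from compound 1 to compound 2 (0.05 log units; within the scatter) and a 1.4-fold lower number from compound 1 to compound 3 (0.13 log units; within the scatter), and both lie within the scatter. For the measured compounds named here, no measured compound carries propanoyl there, so this evidence is indirect. In this assay no change beyond the scatter is therefore expected, and the estimated step is a 1.2-fold higher number from compound 3 to compound 4 (0.06 log units; within the scatter). For compound 4 the expected value is 14 ug/mL, with an estimated range of 7 ug/mL to 28 ug/mL.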

Compound 4, half-maximal inhibitory concentration: 26.8 ug/mL
Beside the measured number, compound 4's estimate is 1.9-fold (0.28 log units) below it; low and high end bracket the measured number.
By their numbers in this assay, from the lowest: compounds 3, 2, 1 and 4 (each within the scatter of the next, the first and the last beyond it).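

In this assay, among the compounds shown here, the groups on this oxygen had so far stayed within the scatter of one another, and propanoyl opens the first step beyond it (a 2.2-fold higher number from compound 3 to compound 4 (0.35 log units; beyond the scatter)). That gap holds only against (allylcarbamoyl)methyl: the other two steps stay within the scatter (a 1.8-fold higher number from compound 2 to compound 4 (0.27 log units; within the scatter); a 1.6-fold higher number from compound 1 to compound 4 (0.21 log units; within the scatter)), so propanoyl is not set apart from allyl or methyl. Nothing measured here accounts for the step. Going by these compounds, it remains open what a longer acyl chain, a benzoyl group or a chain ending in an amine would give on this oxygen.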